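Moving the fluoro group from compound 3 to compound 4

The source may report more compounds than this note shows. Statements on the series, on what has been measured and on what is new or still open speak of the compounds shown alone.

Compound 1 `COc1ccc(-c2nsc3c2NC(=O)CC3c2cccc(OC)c2)cc1` gives 808 nM
Compound 2 `COc1ccc(-c2nsc3c2NC(=O)CC3c2cccc(Cl)c2)cc1` gives 1270 nM
Compound 3 `COc1ccc(-c2nsc3c2NC(=O)CC3c2cccc(F)c2)cc1` gives > 2000 nM (a limit, not a number)

All three results come from a functional assay on TOV112D cells (Homo sapiens) for antiproliferative activity, read by CellTiter-Glo, with a stated time of 96 h; a higher number here means a weaker inhibitor, a lower number a stronger inhibitor. Compound 3 stands at the limit of > 2000 nM in this assay, at which 1 of the 3 values shown sits.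

Compound 4 `COc1ccc(-c2nsc3c2NC(=O)CC3c2ccc(F)cc2)cc1` has the same atoms as compound 3, with 4-fluorophenyl in place of 3-fluorophenyl on a saturated ring carbon.

Three measured steps come closest, though each exchanges the group and none moves it. The clearest is an at least 2.4-fold higher number from compound 1 to compound 3 (0.39 log units; beyond the scatter). The other two are smaller: an at least 1.5-fold higher number from compound 2 to compound 3 (0.19 log units; that floor lies within the scatter) and a 1.6-fold higher number from compound 1 to compound 2 (0.20 log units; within the scatter). They give no direct measure of a shift in the fluoro position, so no direction can be assigned.

The expectation rests mainly on compound 3, whose result is a limit, > 2000 nM. No step beyond the scatter is expected, and the estimated step is a number no higher from compound 3 to compound 4 (the limit leaves the size open). For compound 4 the estimate is 2000 nM, with an expected range of 1000 nM to 4000 nM.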

Compound 4, half-maximal inhibitory concentration: > 2000 nM
Compound 4: no number, only a limit; the forecaster's own chance of this, stated with the estimate: 50%; the middle value sits exactly at the limit.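

In this assay compound 4 reads > 2000 nM, a limit and not a number, and the second such result in this set: the limit of > 2000 nM in this assay, at which 2 of the 4 values shown sit. The step between the two fluorophenyl compounds cannot be read, so these data do not separate 4-fluorophenyl from 3-fluorophenyl on this saturated ring carbon. The readable comparisons are an at least 2.4-fold higher number from compound 1 to compound 4 (0.39 log units; beyond the scatter) and an at least 1.5-fold higher number from compound 2 to compound 4 (0.19 log units; that floor lies within the scatter), so 4-fluorophenyl, like 3-fluorophenyl, has a floor beyond the scatter only against the 3-methoxyphenyl group of compound 1.

Still open, from the compounds shown here alone, is what actual value either fluorophenyl compound has in this assay, and whether the same shift of the methoxy or chloro group would change the result. Also open, going by these compounds, is how an amine or a carboxylic acid on this phenyl ring would read.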